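The source may report more compounds than this note shows. Statements on the series, on what has been measured and on what is new or still open speak of the compounds shown alone.

Of the compounds shown here, three sharing one core have been measured in a functional assay on NCI-H23 cells (Homo sapiens) for inhibition, read by sulforhodamine B assay, with a stated time of 48 h, tested at 10 uM; on this read-out higher numbers stand for more inhibition at the one concentration tested (going by the name of the read-out) and lower numbers for less inhibition. Going by the values given here, compound 1 `Fc1ccccc1-c1cn2ccnc2c(-c2ccc3ncn(C4CCCCC4)c3c2)n1` gives 4.16%, and compound 2 `c1csc(-c2cn3ccnc3c(-c3ccc4ncn(C5CCCCC5)c4c3)n2)c1` gives 5.95%; the only change between them is a number 1.8 percentage points higher from compound 1 to compound 2 (within the scatter), so these two compounds cannot be told apart on this read-out. Compound 3 `CCc1ccc(-c2cn3ccnc3c(-c3ccc4ncn(Cc5ccccc5)c4c3)n2)cc1`, which carries a benzyl group on the fused system instead of a cyclohexyl group and a 4-ethylphenyl group at the other end, gives 23%; this is the highest of the three numbers, and its distance from both compound 2 and compound 1 lies beyond the scatter.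

Compound 4 `c1ccc(Cn2cnc3ccc(-c4nc(-c5cccc6ccccc56)cn5ccnc45)cc32)cc1` is not yet measured. It differs from compound 3 in one place: naphthalen-1-yl in place of 4-ethylphenyl on an aromatic carbon. Among the compounds with values here, the only measured step that touches this position is the one from compound 1 to compound 2, where swapping one aromatic group for another changed the number by an amount within the scatter. On that basis, the step of a number 7 percentage points lower from compound 3 to compound 4 (within the scatter) is expected to stay small, with no clear direction. Compound 4 is therefore estimated to give about 16% in this assay, within a range from 2% to 32%.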

Compound 4, a percentage reported as inhibition, at one concentration (the size of the read-out at that concentration, not a potency): 10.4%
The estimate for compound 4 lay 5.6 percentage points above the measured number; measured number inside the range.
By their numbers in this assay, from the lowest: compounds 1, 2 and 4 (each within the scatter of the next); then compound 3.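

In this assay, replacing 4-ethylphenyl with naphthalen-1-yl on the aromatic carbon next to the ring nitrogen gives a number 12.6 percentage points lower from compound 3 to compound 4 (beyond the scatter) and shows that the group at this position can shift the number by more than the usual scatter. The earlier step at this position, a number 1.8 percentage points higher from compound 1 to compound 2 (within the scatter) and with a cyclohexyl group on the fused system, could not show this, so the new step gives the first sign of a real difference between two groups here, seen so far only with the benzyl group in place. Both groups have no hydrogen-bond donors, acceptors or net charge, and what changes in the count is the carbon framework, with a second six-membered aromatic ring entering, but no measurement shown explains the lower number.

As far as these compounds go, it remains open whether the ethyl group of compound 3 matters, which a plain phenyl group or a 4-butylphenyl group could help to separate from the effect of the ring itself. From the compounds shown here alone, it is also open how an amine or a carboxylic acid on the aryl group would read here, and whether naphthalen-1-yl gives a similar step when a cyclohexyl group replaces the benzyl group.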